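A few compounds are considered here, and "the series" means these few. Any claim that something is new, unique, unknown or untested is made for them only; others in the source may bear on it.

Among the compounds with values here, compound 2, with the structure `COc1ccc(Cn2nc(-c3ccccc3)c3cc(C(=N)Nc4ccccc4)ncc32)cc1`, is the single compound here that carries a number. In a functional assay on PC-3 cells (Homo sapiens) for cytotoxicity, read by MTT assay, with a stated time of 72 h (a higher number here means a weaker inhibitor, a lower number a stronger inhibitor), compound 2 gives 6300 nM. A second compound, compound 1 with the structure `COc1ccc(Cn2nc(-c3ccccc3)c3cc(C(=N)Nc4cccc(C(F)(F)F)c4)nc(NC4CCCCC4)c32)cc1`, belongs to the same family, but in this assay compound 1 gives "not determined" (no result reported), so no step between two measured compounds can be drawn, and compound 2 stands alone on the numbers shown.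

Compound 3 has the structure `COc1ccc(Cn2nc(-c3ccccc3)c3cc(C(=N)Nc4ccccc4)nc(NC4CCCCC4)c32)cc1`. It differs from compound 2 in one place: cyclohexylamino in place of hydrogen on an aromatic carbon. Put in words, a cyclohexylamino group takes the place of a hydrogen on an aromatic carbon of the shared core.

Nothing measured tells how such a change behaves in this assay. Under that uncertainty the step from compound 2 to compound 3 is expected to be small, leaning toward a somewhat lower number, but it may well stay within the scatter, so the expected step is a 1.6-fold lower number from compound 2 to compound 3 (0.20 log units; within the scatter). The estimate for compound 3 in this assay is therefore 4000 nM, with a likely range from 1200 nM to 14000 nM.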

Compound 3, half-maximal inhibitory concentration: 1100 nM
Estimate against measurement, compound 3: 3.6-fold (0.56 log units) above; the whole stated range lies above it.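

In this assay, putting cyclohexylamino in place of hydrogen on this aromatic carbon, next to the ring nitrogen of the shared core, gives a 5.7-fold lower number from compound 2 to compound 3 (0.76 log units; beyond the scatter). Within the data shown here, this is the first sign that the position affects the read-out at all, and here a substantial group on that carbon goes with a stronger result rather than a weaker one. Nothing shown explains why this single change moves the number in this direction.

The compounds shown leave open whether the gain needs the cyclohexyl ring itself or only an amine at this carbon, and a smaller methylamino group, an open-chain hexylamino group or a plain amino group would each separate those possibilities. As far as these compounds go, compound 1 also carries cyclohexylamino and adds a trifluoromethyl group on the outer phenyl ring, but with "not determined" (no result reported) for compound 1, its steps to the other compounds cannot be read, so how a change on that outer ring behaves alongside cyclohexylamino also remains unknown.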